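From cyano to trifluoromethyl: an expected clearance in rat

The source may hold more compounds than are shown below. What is called first, only, known or untested is meant among the compounds shown, and "the series" means these compounds.

Measured in an in vivo ADME assay on the whole organism (plasma, strain Sprague-Dawley) for pharmacokinetics, with Rattus norvegicus as the target; a lower number here means slower removal, a higher number faster removal of the compound
Compound 1 `Cc1cc(CCC(=O)O)ccc1-c1noc(-c2ccc(OC(C)C)c(C#N)c2)n1` gives 2.3 mL/min/kg
Compound 2 `Cc1cc([C@H]2C[C@H]2C(=O)O)ccc1-c1noc(-c2ccc(OC(C)C)c(C#N)c2)n1` gives 1.2 mL/min/kg

Among the compounds with values here, compound 1 has only one neighbour among the measured compounds, and the two numbers lie within the scatter of each other. That one comparison is a 1.9-fold lower number from compound 1 to compound 2 (0.28 log units; within the scatter), with 2-carboxycyclopropyl in place of 2-carboxyethyl on an aromatic carbon.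

Compound 3 `Cc1cc(CCC(=O)O)ccc1-c1noc(-c2ccc(OC(C)C)c(C(F)(F)F)c2)n1` keeps the 2-carboxyethyl of compound 1 and changes another place, with trifluoromethyl in place of cyano on an aromatic carbon. Within the data shown here, no measured step replaces the cyano, so the only step available shows scale and not the effect of this change. No shift in this assay beyond the scatter is therefore expected, and no direction can be given. The expected step is a 1.1-fold higher number from compound 1 to compound 3 (0.04 log units; within the scatter). For compound 3 the estimated clearance is 2.5 mL/min/kg, with an expected range of 1.1 mL/min/kg to 5.5 mL/min/kg.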

Compound 3, clearance: 8.7 mL/min/kg
For compound 3 the middle estimate is 3.5-fold (0.54 log units) below the measured one; measured number outside the range, above it.
By their numbers in this assay, from the lowest: compounds 2 and 1 (each within the scatter of the next); then compound 3.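

In this assay the position ortho to an isopropoxy group proves sensitive to what sits on it: trifluoromethyl in place of the nitrile gives a 3.8-fold higher number from compound 1 to compound 3 (0.58 log units; beyond the scatter), a modest step but one that clears the scatter. Within the data shown here, the only earlier comparison, in the 2-carboxyethyl chain, gave a 1.9-fold lower number from compound 1 to compound 2 (0.28 log units; within the scatter), so of the two places varied from compound 1, this is the one where a change shows beyond the scatter. Nothing measured here bears on what lies behind the rise with trifluoromethyl.

The compounds shown leave open whether other groups on this carbon, such as a chlorine atom, a methyl or an amide, would fall with the nitrile or with trifluoromethyl. They also leave open whether the same exchange would give a comparable step when carried onto the 2-carboxycyclopropyl chain of compound 2.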